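Changing the aryl group on a triazole-linked phenol ester

The compounds below may be only part of what the source reports. "The series", "measured", "known", "first", "only" and "open" are said of these compounds alone.

Measured compounds:
compound 1, `COC(=O)c1cc(-n2cc(-c3cccc(O)c3)nn2)ccc1O`, 5%
compound 2, `O=C(OCCCc1ccccc1)c1cc(-n2cc(-c3cccc(O)c3)nn2)ccc1O`, 9%

The two measured compounds share a core and were tested in a functional assay on CCRF-CEM cells (Homo sapiens) for inhibition, read by MTT assay, with a stated time of 2 days, tested at 10 uM; on this read-out higher numbers stand for more inhibition at the one concentration tested (going by the name of the read-out) and lower numbers for less inhibition. Compound 1 gives 5%, the lowest of the two numbers, and compound 2 gives 9%; the step of a number 4 percentage points higher from compound 1 to compound 2 (within the scatter) is within the scatter, so the two values are not told apart. That step concerns only the ester side of the molecule, where phenethyl replaces hydrogen on a saturated chain carbon bound to an oxygen next to a carbonyl group.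

Compound 3, `COC(=O)c1cc(-n2cc(-c3ccccc3OC)nn2)ccc1O`, is not yet measured. It differs from compound 1 at the other end of the core: 2-methoxyphenyl in place of 3-hydroxyphenyl on an aromatic carbon. Within the data shown here, no measured step touches this aromatic carbon of the five-membered ring, so nothing among the measured compounds shows how this assay answers to a change there. With both measured values low and close together, the expected step from compound 1 to compound 3 is a number 3 percentage points higher from compound 1 to compound 3 (within the scatter), that is none beyond the scatter. For compound 3 the estimate in this assay is 8%, within -6% to 24%.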

Compound 3, a percentage reported as inhibition, at one concentration (the size of the read-out at that concentration, not a potency): 6%
For compound 3 the middle estimate is 2 percentage points above the measured one; low and high end bracket the measured number.
By their numbers in this assay, from the lowest: compounds 1, 3 and 2 (each within the scatter of the next).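

In this assay, among these compounds, the exchange on the aromatic carbon of the five-membered aromatic ring gives a number 1 percentage points higher from compound 1 to compound 3 (within the scatter) and is the first measured step at this position, so 2-methoxyphenyl and 3-hydroxyphenyl are not told apart here. The group that leaves carries 1 hydrogen-bond donor and the group that enters carries 0 hydrogen-bond donors, yet this pair shows no difference beyond the scatter, which is as far as a single exchange between two low values can go. No measurement at hand speaks to the reason for this result.

The compounds shown leave open whether any group on this aromatic carbon can raise the number in this assay beyond the scatter, since only these two aryl groups have been compared there and both give low values. Going by these compounds, it also remains open how an aryl group bearing an amine or a carboxylic acid would read in this position, and whether 2-methoxyphenyl would give a different number when combined with the longer ester chain of compound 2.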